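Dimethoxyphenyl in Place of Dichlorophenyl on the Saturated Carbon

The compounds below may be only part of what the source reports. "The series", "measured", "known", "first", "only" and "open" are said of these compounds alone.

In a functional assay on BGC-823 cells (Homo sapiens) for antiproliferative activity, read by MTT assay, tested at 5 uM (a lower number here means a weaker effect, a higher number a stronger effect of the compound at the concentration tested), compound 2 `COc1cc(C2=NN(C(C)=O)C(c3cc(Cl)cc(Cl)c3)O2)cc(OC)c1OC` gives 6.6%, and compound 1 `COc1cc(C2=NN(C(C)=O)C(c3c(Cl)cccc3Cl)O2)cc(OC)c1OC` gives 15.9%, the two numbers lying within the scatter of each other. Compound 3 `COc1cc(C2=NN(C(C)=O)C(c3cccc(OC)c3OC)O2)cc(OC)c1OC` differs from compound 2 by 2,3-dimethoxyphenyl in place of 3,5-dichlorophenyl on a saturated ring carbon. Within the data shown here, the only measured step, a number 9.3 percentage points lower from compound 1 to compound 2 (within the scatter), exchanges one dichlorophenyl for another and therefore offers no direct guide to a dimethoxyphenyl entering at this carbon. With nothing pointing beyond the scatter, compound 3 is expected to give 10%, between 0% and 25%, which is expected to mean a step of a number 3.4 percentage points higher from compound 2 to compound 3 (within the scatter) that stays within the scatter.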

Compound 3, a percentage reported as inhibition, at one concentration (the size of the read-out at that concentration, not a potency): 17.5%
Beside the measured number, compound 3's estimate is 7.5 percentage points below it; measured number inside the range.
By their numbers in this assay, from the lowest: compounds 2, 1 and 3 (each within the scatter of the next, the first and the last beyond it).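

In this assay, among these compounds, the replacement of one dichlorophenyl by 2,3-dimethoxyphenyl gives the first change at this saturated ring carbon to pass beyond the scatter: a number 10.9 percentage points higher from compound 2 to compound 3 (beyond the scatter). The result depends on which dichlorophenyl leaves, since the other comparison gives a number 1.6 percentage points higher from compound 1 to compound 3 (within the scatter). Nothing available explains this difference between the two comparisons.

From the compounds shown here alone, it remains open whether a phenyl bearing a single methoxy group would read like the 2,3-dimethoxyphenyl. Also open, going by these compounds, is how an amine or a carboxylic acid on that phenyl would fare at this carbon.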